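From trifluoromethyl to carbamoyl: compound 3 to compound 4

This account rests on a few compounds, and the source may have more. Where it says the series, first, only, none or still open, it means among the compounds named here.

In a physicochemical assay for lipophilicity, at pH 7.4 (on this read-out lower numbers stand for lower lipophilicity and higher numbers for higher lipophilicity), compound 3 `Cc1cc(CCC#N)cc(C)c1Oc1cc(Nc2ccc(C#N)cc2)c(N)cc1C(F)(F)F` reads > 5, which is a limit and not a number. Compound 4 `Cc1cc(CCC#N)cc(C)c1Oc1cc(Nc2ccc(C#N)cc2)c(N)cc1C(N)=O` carries carbamoyl in place of trifluoromethyl on an aromatic carbon. Compound 1 `CNC(=O)c1cc(N)c(Nc2ccc(C#N)cc2)cc1Oc1c(C)cc(CCC#N)cc1C`, with methylcarbamoyl at that carbon, gives 2.65 and is the closest measured comparison. Compound 2 `Cc1cc(CCC#N)cc(C)c1Oc1cc(Nc2ccc(C#N)cc2)c(N)cc1CO`, with hydroxymethyl there, gives 3.68. All three measured steps are large and beyond the scatter: a number 1.03 log units higher from compound 1 to compound 2 (beyond the scatter), a number at least 2.35 log units higher from compound 1 to compound 3 (beyond the scatter) and a number at least 1.32 log units higher from compound 2 to compound 3 (beyond the scatter). The last two bear most directly, and a large fall in this assay is therefore expected, estimated as a number at least 2.60 log units lower from compound 3 to compound 4 (beyond the scatter). For compound 4 the estimated value is 2.4, with an expected range from 1.9 to 3.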

Compound 4, partition coefficient: 2.65
Compound 4: the middle estimate sits 0.25 log units below what was measured; the measured number falls inside the stated range.
By their numbers in this assay, from the lowest: compounds 1 and 4 (each within the scatter of the next); then compound 2. At a limit, above all of these: compound 3.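

In this assay carbamoyl on this aromatic carbon gives a number at least 2.35 log units lower from compound 3 to compound 4 (beyond the scatter) and a number 1.03 log units lower from compound 2 to compound 4 (beyond the scatter) on the same carbon. Hydrogen in place of methyl on the amide-type nitrogen gives no change at the digits printed from compound 1 to compound 4 (within the scatter) for this pair of amides. Compound 3 stands at a limit and not a number: the limit of > 5 in this assay, at which 1 of the 4 values shown sits.

From the compounds shown here alone, how far compound 3 lies past its limit stays open. Also open, going by these compounds, is where dimethylcarbamoyl, a carboxylic acid or aminomethyl on this carbon would fall relative to compound 1 and compound 4.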